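Swapping Methoxy for Fluoro on the Outer Ring

A few compounds are considered here, and "the series" means these few. Any claim that something is new, unique, unknown or untested is made for them only; others in the source may bear on it.

Compound 1 `COc1ccc(-c2cnc(Nc3ccc(C#N)cc3)nc2Oc2c(C)cc(C#N)cc2C)cc1` sits at the edge of what an ADME assay on MT4 cells (Homo sapiens) for cytotoxicity, read by MTT assay, with a stated time of 5 days (on this read-out higher numbers stand for lower toxicity in this test and lower numbers for higher toxicity in this test), can report: in this assay compound 1 gives only a limit of > 279000 nM, not a measured number. Compound 2 `Cc1cc(C#N)cc(C)c1Oc1nc(Nc2ccc(C#N)cc2)ncc1-c1ccc(C(F)(F)F)cc1` in this assay gives 35000 nM, and the step of an at least 7.9-fold lower number from compound 1 to compound 2 (0.90 log units; beyond the scatter) is the only measured one here; it shares with the change now considered the departure of methoxy. Compound 3 `Cc1cc(C#N)cc(C)c1Oc1nc(Nc2ccc(C#N)cc2)ncc1-c1ccc(F)cc1` differs from compound 1 by fluoro in place of methoxy on an aromatic carbon. A downward step of modest size is therefore expected, and compound 3 is estimated at 100000 nM (range 30000 nM to 300000 nM), an expected step of an at least 2.7-fold lower number from compound 1 to compound 3 (0.44 log units; beyond the scatter).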

Compound 3, half-maximal cytotoxic concentration: 42700 nM
Estimate against measurement, compound 3: 2.3-fold (0.37 log units) above, within the range that was stated.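

Replacing methoxy with fluoro gives an at least 6.5-fold lower number from compound 1 to compound 3 (0.81 log units; beyond the scatter), so the fall seen with trifluoromethyl is not unique to that group. Between the two replacements there is a 1.2-fold higher number from compound 2 to compound 3 (0.09 log units; within the scatter), so this assay cannot tell fluoro and trifluoromethyl apart at this position. The full size of each step away from compound 1 remains unknown, as compound 1 gives only a limit: the limit of > 279000 nM in this assay, at which 1 of the 3 values shown sits.

As far as these compounds go, whether methoxy alone stands apart remains open. An amine or a longer chain such as ethoxy at this position could fall on either side.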